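The source may hold more compounds than are shown below. What is called first, only, known or untested is meant among the compounds shown, and "the series" means these compounds.

Compound 1 `C=C[C@@](C)(/C=C/c1ccc(O)c(/C=C/C#N)c1)CCC=C(C)C`: > 43400 nM
Compound 2 `C=C[C@@](C)(/C=C/c1ccc(O)c(/C=C/C(=O)OCC)c1)CCC=C(C)C`: 20900 nM

Both compounds were tested in a functional assay on NALM-6 cells (Homo sapiens) for cytotoxicity, with a stated time of 72 h; on this read-out higher numbers stand for an effect only at larger amounts of compound and lower numbers for an effect already at smaller amounts. Compound 1 reads > 43400 nM, which is a limit of the assay and not a number. For the measured compounds named here, compound 2 gives 20900 nM, the only true number so far, so it has no measured value to be ranked against.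

Compound 3 `C=C[C@@](C)(/C=C/c1ccc(O)c(/C=C/C(=O)OCc2ccccc2)c1)CCC=C(C)C` is still unmeasured. The change is phenyl in place of methyl on a saturated chain carbon bound to an oxygen next to a carbonyl group, or ethoxycarbonyl to benzyloxycarbonyl.

Going by the values given here, the one measured step, an at least 2.0-fold lower number from compound 1 to compound 2 (0.31 log units; beyond the scatter), put ethoxycarbonyl in place of cyano. It bears on this change only loosely, since it did not alter the ethyl part. No step beyond the scatter is therefore expected, with a slight lean towards lower numbers.

The expected change is a 1.4-fold lower number from compound 2 to compound 3 (0.14 log units; within the scatter).

For compound 3 the estimated value is 15000 nM, with an expected range of 6000 nM to 40000 nM.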

Compound 3, half-maximal effective concentration: > 43400 nM
Compound 3 gave a limit, no number (the forecaster's own chance of this, stated with the estimate: 20%); at least 2.8-fold (0.46 log units) between middle value and limit.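

In this assay, the earlier step showed only that an ester could read better than the nitrile; this result shows that the group on the ester oxygen matters too. Putting phenyl in place of methyl on a saturated chain carbon bound to an oxygen next to a carbonyl group, which turns ethoxycarbonyl into benzyloxycarbonyl, gives an at least 2.0-fold higher number from compound 2 to compound 3 (0.31 log units; beyond the scatter), so keeping the ester is not enough to keep a measurable effect. Compound 1 and compound 3 both stop at a limit of the assay and not at a number, so the step between them cannot be read: the limit of > 43400 nM in this assay, at which 2 of the 3 values shown sit.

As far as these compounds go, how far compound 3 lies past its limit stays open. Also open, from the compounds shown here alone, is whether a methyl ester, an amide or a carboxylic acid in this place would give a lower number than compound 2.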